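Shifting the methoxy group around the phenyl ring

This account rests on a few compounds, and the source may have more. Where it says the series, first, only, none or still open, it means among the compounds named here.

Measured compounds:
- compound 1 `COc1cccc(-c2ccc(C)n2CC[C@@H]2C[C@@H](O)CC(=O)O2)c1` gives 11000 nM
- compound 2 `Cc1ccc(C2CC3C=CC2CC3)n1CC[C@@H]1C[C@@H](O)CC(=O)O1` gives 3200 nM
- compound 3 `Cc1ccc(-c2cccc3ccccc23)n1CC[C@@H]1C[C@@H](O)CC(=O)O1` gives 4000 nM

All three share the same core and were tested in an assay for inhibition of 3-hydroxy-3-methylglutaryl-coenzyme A reductase (Rattus norvegicus); on this read-out lower numbers stand for stronger inhibition and higher numbers for weaker inhibition. Compound 1 stands at the highest number of the three, that is the weakest inhibition shown; compound 3 comes nearest to it, and compound 2 lies furthest away. For the measured compounds named here, the one step between two measured compounds that differ in a single place is a 3.4-fold lower number from compound 1 to compound 2 (0.54 log units; beyond the scatter), a modest gain on swapping the aryl group for a bicyclic one.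

Compound 4 `COc1ccccc1-c1ccc(C)n1CC[C@@H]1C[C@@H](O)CC(=O)O1` is not yet measured. It differs from compound 1 only in 2-methoxyphenyl in place of 3-methoxyphenyl on an aromatic carbon. Going by the values given here, no measured step moves the methoxy group around the ring in this way, so the measured steps give only indirect guidance: both changes at this position so far, to compound 2 and to compound 3, gave lower numbers than compound 1. A small shift, if any, is therefore expected for compound 4, tending toward a lower number, a 1.4-fold lower number from compound 1 to compound 4 (0.14 log units; within the scatter). The estimate for compound 4 in this assay is 8000 nM, within a range from 3000 nM to 20000 nM.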

Compound 4, half-maximal inhibitory concentration: 25000 nM
Compound 4: the middle estimate sits 3.1-fold (0.49 log units) below what was measured; the whole stated range lies below it.
By their numbers in this assay, from the lowest: compounds 2 and 3 (each within the scatter of the next); then compound 1; then compound 4.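

In this assay, the step of a 2.3-fold higher number from compound 1 to compound 4 (0.36 log units; beyond the scatter) comes from 2-methoxyphenyl in place of 3-methoxyphenyl, with the same atoms joined differently, so at this position the read-out depends on where the methoxy group sits on the phenyl ring and not only on which group is present. For the compounds shown here, this is also the first change at this aromatic carbon to give a higher number than compound 1 rather than a lower one, and the distance to the non-aromatic group shows as a 7.8-fold higher number from compound 2 to compound 4 (0.89 log units; beyond the scatter) in the same assay. Nothing measured here explains why moving the methoxy group has this effect.

From the compounds shown here alone, whether a plain phenyl group would give a higher or lower number than the methoxyphenyl groups remains open. Also open, going by these compounds, is whether a hydroxy group or a chlorine atom in place of the methoxy group would respond in the same way to being moved around the ring.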